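A few compounds are considered here, and "the series" means these few. Any claim that something is new, unique, unknown or untested is made for them only; others in the source may bear on it.

Measured in a functional assay on L1210 cells (Mus musculus), with a stated time of 1 days; on this read-out higher numbers stand for higher potency (the scale is a negative logarithm) and lower numbers for lower potency:
compound 1 `CC1=C(N2CC2)C(=O)C(CC(C)OC(N)=O)=C(N2CC2)C1=O`: 5.86
compound 2 `CCC1=C(N2CC2)C(=O)C(C(COC(N)=O)OC)=C(N2CC2)C1=O`: 5.62
compound 3 `COCCC1=C(N2CC2)C(=O)C(CCOC)=C(N2CC2)C1=O`: 5.18

Compound 1 holds the highest of the three numbers. Compound 2 lies within the usual scatter of compound 1, so no order between these two can be read; compound 3 lies beyond the scatter below compound 1. Among the compounds with values here, no two measured compounds differ in one place only, so no single step is on record.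

Compound 4 `CC1=C(N2CC2)C(=O)C(CCCc2ccccc2)=C(N2CC2)C1=O` is not yet measured. Against compound 1 the change is a group of 8 heavy atoms (8 carbon; one six-membered aromatic ring of carbon only) in place of a group of 6 heavy atoms (3 carbon, 1 nitrogen, 2 oxygen; no ring), on a saturated chain carbon bound to a double-bonded ring carbon: phenethyl enters in place of a group with no ring, on a saturated chain carbon bound to a double-bonded ring carbon. In this assay a drop beyond the scatter is expected, the step from compound 1 to compound 4 being estimated at a number 0.56 log units lower from compound 1 to compound 4 (beyond the scatter). For compound 4 the estimate is 5.3, expected to fall between 4.8 and 5.8.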

Compound 4, logarithm of the reciprocal of the active concentration, log(1/C): 3.93
For compound 4 the middle estimate is 1.37 log units above the measured one; the measured number lies below the stated range.
By their numbers in this assay, from the lowest: compound 4; then compound 3; then compounds 2 and 1 (each within the scatter of the next).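

In this assay, within the data shown here, this position proves sensitive to the substituent: phenethyl entering in place of the ringless carbamate-bearing group gives a number 1.93 log units lower from compound 1 to compound 4 (beyond the scatter) and this is the first single step on record. The earlier compounds shown here tied no number to a change at this position alone. Nothing measured here accounts for the drop.

Still open, on these data alone, is whether the drop goes with the loss of the carbamate or with the arrival of the aromatic ring. A propyl group or a hydroxyethyl group in the same place would help separate the two.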